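A few compounds are considered here, and "the series" means these few. Any claim that something is new, unique, unknown or untested is made for them only; others in the source may bear on it.

Of the compounds shown here, three sharing one core have been tested in a functional assay on HEL cells (Homo sapiens) for cytotoxicity, read by microscopy; on this read-out lower numbers stand for higher toxicity in this test and higher numbers for lower toxicity in this test. Compound 1 `Cc1cn([C@@H]2O[C@H](CO[Si](C)(C)C(C)(C)C)[C@@]3(OS(=O)(=O)C=C3NCCC(=O)OCc3ccccc3)[C@H]2O[Si](C)(C)C(C)(C)C)c(=O)n(C)c1=O` gives only a limit of the assay, >= 400000 nM. Compound 2 `COC(=O)CC(=O)NC1=CS(=O)(=O)O[C@@]12[C@@H](CO[Si](C)(C)C(C)(C)C)O[C@@H](n1cc(C)c(=O)n(C)c1=O)[C@@H]2O[Si](C)(C)C(C)(C)C` gives 400000 nM in this assay. Compound 3 `CCOC(=O)CNC(=O)NC1=CS(=O)(=O)O[C@@]12[C@@H](CO[Si](C)(C)C(C)(C)C)O[C@@H](n1cc(C)c(=O)n(C)c1=O)[C@@H]2O[Si](C)(C)C(C)(C)C` gives 16000 nM, the lower of the two plain numbers shown, and its nearest neighbour is compound 2, reached by the step of a 25-fold lower number from compound 2 to compound 3 (1.40 log units; beyond the scatter), which lies beyond the scatter; the step of an at least 25-fold lower number from compound 1 to compound 3 (1.39 log units; beyond the scatter) is likewise beyond the scatter. Both of these steps replace a chain lacking a carbamoyl group by one carrying the ((ethoxycarbonyl)methyl)carbamoyl group, and both bring the number down, that is, toward higher toxicity.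

Compound 4 `Cc1cn([C@@H]2O[C@H](CO[Si](C)(C)C(C)(C)C)[C@@]3(OS(=O)(=O)C=C3NCC(=O)C(N)=O)[C@H]2O[Si](C)(C)C(C)(C)C)c(=O)n(C)c1=O` has not yet been measured in this assay. It differs from compound 3 by (carbamoylcarbonyl)methyl in place of ((ethoxycarbonyl)methyl)carbamoyl on an amine nitrogen. This change removes the carbamoyl group that the two measured steps tie to the lower number, and the chain that enters resembles in kind those of compound 1 and compound 2, which sit at the high end. The expectation is therefore a higher number for compound 4, a step of about a 13-fold higher number from compound 3 to compound 4 (1.10 log units; beyond the scatter). Compound 4 is expected to give around 200000 nM in this assay, between 40000 nM and 400000 nM.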

Compound 4, minimum cytotoxic concentration: >= 16000 nM
Compound 4: a limit, no number; the forecaster's own chance of this, stated with the estimate: 40%; the middle value lies beyond the limit too.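

Compound 4 gives no number in this assay, only a limit of the assay: the limit of >= 16000 nM in this assay, at which 1 of the 4 values shown sits.

On the amine nitrogen, putting (carbamoylcarbonyl)methyl in place of ((ethoxycarbonyl)methyl)carbamoyl gives a number no lower from compound 3 to compound 4 (the limit leaves the size open), which means that this shorter chain, with no ester in it, does not push the read-out toward higher toxicity than the chain it replaces. The steps linking compound 4 to compound 1 and to compound 2 cannot be read, leaving compound 4 unplaced against those two, while compound 3 still holds the lowest plain number of the set.

Still open, going by these compounds, is how far the number for compound 4 really lies from that of compound 3: it could sit close to it or up among the high readings of compound 1 and compound 2, and only a test reaching higher concentrations could tell these apart. Also open, on these data alone, is which part of the chain in compound 3 goes with its lower number, something a carboxylic acid in place of the ethyl ester, or a longer chain on the same nitrogen, could begin to separate.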